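This account rests on a few compounds, and the source may have more. Where it says the series, first, only, none or still open, it means among the compounds named here.

In a functional assay with Homo sapiens as the target (a lower number here means a stronger inhibitor, a higher number a weaker inhibitor), compound 1 `CC(C)[C@H](NC(=O)COc1cccc2ccccc12)C(=O)N[C@@H](CC(=O)O)C(=O)COc1ccc(C(F)(F)F)cc1` gives 12300 nM, compound 2 `CC(C)[C@H](NC(=O)COc1cccc2ccccc12)C(=O)N[C@@H](CC(=O)O)C(=O)COc1ccc([N+](=O)[O-])cc1` gives 22800 nM and compound 3 `CC(C)[C@H](NC(=O)COc1cccc2ccccc12)C(=O)N[C@@H](CC(=O)O)C(=O)COc1c(F)c(F)c(F)c(F)c1F` gives 8890 nM. The three differ only in the group on an oxygen on a saturated carbon. Compound 3 sits at the low end of these numbers, a place it shares with compound 1 within the scatter. The measured steps show how little this group has moved the read-out so far: a 1.4-fold lower number from compound 1 to compound 3 (0.14 log units; within the scatter), a 1.9-fold higher number from compound 1 to compound 2 (0.27 log units; within the scatter), and the only one to pass the scatter, a 2.6-fold lower number from compound 2 to compound 3 (0.41 log units; beyond the scatter).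

Compound 4 `CC(C)[C@H](NC(=O)COc1cccc2ccccc12)C(=O)N[C@@H](CC(=O)O)C(=O)COc1cccc(C(F)(F)F)c1F` has not yet been measured. It carries 2-fluoro-3-(trifluoromethyl)phenyl in place of 2,3,4,5,6-pentafluorophenyl on an oxygen on a saturated carbon. Among the compounds with values here, all three measured steps replace a group at this same place, so they are the guide to the size of this one, although none of the measured compounds carries the incoming group. Compound 1 also bears a trifluoromethyl group and gives 12300 nM, which suggests a value near that of compound 1. The expected change in this assay is therefore small, an estimated 1.2-fold higher number from compound 3 to compound 4 (0.09 log units; within the scatter), with no shift beyond the scatter. For compound 4 the estimate is 11000 nM, with an expected range of 5000 nM to 24000 nM.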

Compound 4, half-maximal inhibitory concentration: 18200 nM
Compound 4: the middle estimate sits 1.7-fold (0.22 log units) below what was measured, within the range that was stated.
By their numbers in this assay, from the lowest: compounds 3, 1, 4 and 2 (each within the scatter of the next, the first and the last beyond it).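

In this assay the group on an oxygen on a saturated carbon now gives a second step beyond the scatter, a 2.0-fold higher number from compound 3 to compound 4 (0.31 log units; beyond the scatter), and both steps of that size involve the 2,3,4,5,6-pentafluorophenyl of compound 3, although its step to compound 1 stays within the scatter. The incoming 2-fluoro-3-(trifluoromethyl)phenyl does not set itself apart from the two groups with a single substituent on the ring, as shown by a 1.3-fold lower number from compound 2 to compound 4 (0.10 log units; within the scatter) and a 1.5-fold higher number from compound 1 to compound 4 (0.17 log units; within the scatter), so a second trifluoromethyl-bearing ring adds a point inside the existing spread rather than a new level. Nothing available explains why these groups differ as they do.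

As far as these compounds go, all four values lie in the narrow span from compound 3 at 8890 nM to compound 2 at 22800 nM, so it remains open whether any group at this place can move the read-out much further. The compounds shown also leave open what an unsubstituted phenyl, a phenyl carrying an amine or a carboxylic acid, or a saturated alkyl chain on this oxygen would give.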